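Removing One Trifluoromethyl Group from Compound 3

The source may report more compounds than this note shows. Statements on the series, on what has been measured and on what is new or still open speak of the compounds shown alone.

Among the measured compounds shown here, compound 3 `COc1cc(Cl)cc(-c2nn(-c3cccc(NC(=O)Nc4cc(C(F)(F)F)cc(C(F)(F)F)c4)c3)cc2-c2ccncc2)c1` stands at the bottom of the three numbers measured so far: in a functional assay on HT-29 cells (Homo sapiens) for inhibition, read by sulforhodamine B assay, with a stated time of 48 h, tested at 1 uM (on this read-out lower numbers stand for a stronger effect and higher numbers for a weaker effect at the one concentration tested), compound 3 gives 23%, while compound 2 `O=C(Nc1cccc(-n2cc(-c3ccncc3)c(-c3cc(O)cc(Cl)c3)n2)c1)Nc1ccc(Cl)c(Cl)c1` gives 96% and compound 1 `O=C(Nc1cccc(-n2cc(-c3ccncc3)c(-c3cc(O)cc(Cl)c3)n2)c1)Nc1ccc(Cl)c(C(F)(F)F)c1` gives 99%, both lying beyond the scatter above compound 3. Compound 4 `COc1cc(Cl)cc(-c2nn(-c3cccc(NC(=O)Nc4cccc(C(F)(F)F)c4)c3)cc2-c2ccncc2)c1` differs from compound 3 in one place: hydrogen in place of trifluoromethyl on an aromatic carbon. For the measured compounds named here, the only measured step that touches a substituent of this kind is a number 3 percentage points lower from compound 1 to compound 2 (within the scatter), which exchanges trifluoromethyl for chloro elsewhere in the molecule and stays within the scatter; no measured step removes a trifluoromethyl group outright. With that single, indirect precedent, compound 4 is expected to keep much of the effect of compound 3 but to lose part of it, because compound 3 sits at 23% while every other measured compound sits far higher. The estimated step is a number 22 percentage points higher from compound 3 to compound 4 (beyond the scatter). Compound 4 is therefore estimated at 45% in this assay, within a range from 20% to 80%.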

Compound 4, a percentage reported as activity, at one concentration (the size of the read-out at that concentration, not a potency): 65%
Compound 4: the middle estimate sits 20 percentage points below what was measured; the measured number falls inside the stated range.
By their numbers in this assay, from the lowest: compound 3; then compound 4; then compounds 2 and 1 (each within the scatter of the next).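

Replacing this trifluoromethyl group, on an aromatic carbon and meta to the remaining trifluoromethyl group, with hydrogen gives a number 42 percentage points higher from compound 3 to compound 4 (beyond the scatter) in this assay and shows that the read-out responds strongly to what this position carries. Among the compounds shown here, the one earlier step, a number 3 percentage points lower from compound 1 to compound 2 (within the scatter), stayed within the scatter and gave no sign that a single change could move the number this far. Compound 4 keeps one trifluoromethyl group, yet that group alone does not preserve the number seen for compound 3. Nothing shown here explains the size of this step.

What the compounds leave open is whether a different group at this position, such as a nitrile or an amine, would match trifluoromethyl or fall closer to hydrogen. They also leave open what removing the remaining trifluoromethyl group would do.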